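Lengthening a Side Chain and Its Effect on Cell Inhibition

The compounds below may be only part of what the source reports. "The series", "measured", "known", "first", "only" and "open" are said of these compounds alone.

Three compounds built on one shared core were measured in a functional assay on A549 cells (Homo sapiens) for inhibition, read by CCK-8 assay, with a stated time of 72 h, tested at 1 uM; on this read-out higher numbers stand for a stronger effect at the one concentration tested and lower numbers for a weaker effect. Compound 1 `CN(C)C(=O)c1cc2cnc(Nc3ccc(S(=O)(=O)NCCCN=C=S)cc3)nc2n1C1CCCC1` gives 58.9% in this assay. Compound 2 `CN(C)C(=O)c1cc2cnc(Nc3ccc(S(=O)(=O)NCCCCN=C=S)cc3)nc2n1C1CCCC1` carries the change a group of 4 heavy atoms (2 carbon, 1 nitrogen, 1 sulfur; no ring) in place of a group of 3 heavy atoms (1 carbon, 1 nitrogen, 1 sulfur; no ring), on a saturated chain carbon, three bonds along the chain from a sulfonamide nitrogen and in this assay compound 2 gives 39.4%, that is a number 19.5 percentage points lower from compound 1 to compound 2 (beyond the scatter). Compound 3 `CN(C)C(=O)c1cc2cnc(Nc3ccc(C(=O)NCCCCN=C=S)cc3)nc2n1C1CCCC1` differs from compound 1 in its core by a group of 10 heavy atoms (6 carbon, 2 nitrogen, 1 oxygen, 1 sulfur; no ring) in place of a group of 10 heavy atoms (4 carbon, 2 nitrogen, 2 oxygen, 2 sulfur; no ring), on an aromatic carbon; in this assay compound 3 gives 30.2%, which is a number 28.7 percentage points lower from compound 1 to compound 3 (beyond the scatter) and a number 9.2 percentage points lower from compound 2 to compound 3 (within the scatter).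

Compound 4 `CN(C)C(=O)c1cc2cnc(Nc3ccc(C(=O)NCCCCCN=C=S)cc3)nc2n1C1CCCC1` has not yet been measured in this assay. It differs from compound 3 by a group of 4 heavy atoms (2 carbon, 1 nitrogen, 1 sulfur; no ring) in place of a group of 3 heavy atoms (1 carbon, 1 nitrogen, 1 sulfur; no ring), on a saturated chain carbon, four bonds along the chain from an amide-type nitrogen. This is the same kind of change as that from compound 1 to compound 2, though not the same: there the place was three bonds along the chain from a sulfonamide nitrogen, here it is four bonds along the chain from an amide-type nitrogen. Because the earlier step was a number 19.5 percentage points lower from compound 1 to compound 2 (beyond the scatter), compound 4 is expected to show a step of a number 15.2 percentage points lower from compound 3 to compound 4 (beyond the scatter) from the value of compound 3. This rests on one earlier example only. Compound 4 is thus estimated at 15%, with a likely range from 0% to 32%.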

Compound 4, a percentage reported as inhibition, at one concentration (the size of the read-out at that concentration, not a potency): 29.3%
For compound 4 the middle estimate is 14.3 percentage points below the measured one, and the stated range covers the measured number.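

The same chain lengthening does not carry over unchanged from one core to the other in this assay: the same change on two cores in this assay, a number 19.5 percentage points lower (beyond the scatter) from compound 1 to compound 2 and a number 0.9 percentage points lower (within the scatter) from compound 3 to compound 4, 18.6 percentage points apart, beyond the scatter of two such steps On the amide compounds the step is a number 0.9 percentage points lower from compound 3 to compound 4 (within the scatter), while the comparisons with the sulfonamide compounds give a number 10.1 percentage points lower from compound 2 to compound 4 (beyond the scatter) and a number 29.6 percentage points lower from compound 1 to compound 4 (beyond the scatter), though each of these also changes the link to the aromatic ring, so neither isolates the chain length. Two pairs show that the effect of this change depends on its surroundings, but they do not explain why, and a reading at one concentration says nothing about potency.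

Going by these compounds, it remains open how a still longer chain would behave on either core, and whether the sulfonamide compounds would keep falling as the chain grows. Also open, on these data alone, is what would happen if the group at the chain end gave way to an amine or a carboxylic acid.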